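The source may report more compounds than this note shows. Statements on the series, on what has been measured and on what is new or still open speak of the compounds shown alone.

Measured so far:
- compound 1, `COc1cc(Cc2nc3c(N)nc(F)nc3n2CCOC(C)C)cc(OC)c1OC`: 15800 nM
- compound 2, `CCC(CC)Cn1c(Cc2cc(OC)c(OC)c(OC)c2)nc2c(N)ncnc21`: 158000 nM
- compound 3, `CCCCn1c(Cc2c(Br)c(OC)c(OC)c(OC)c2Br)nc2c(N)ncnc21`: 30200 nM

In a functional assay on MCF7 cells (Homo sapiens) for antiproliferative activity (a higher number here means a weaker inhibitor, a lower number a stronger inhibitor), compound 1 gives the lowest of the three numbers. Compound 3, with 30200 nM, lies within the scatter of compound 1, so no order between the two can be claimed. Compound 2, with 158000 nM, lies beyond the scatter and is the weaker of that pair.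

Compound 4, `CC[C@H](C)Cn1c(Cc2cc(OC)c(OC)c(OC)c2)nc2c(N)nc(F)nc21`, is not yet measured. It differs from compound 1 in one place: sec-butyl in place of isopropoxymethyl on a saturated chain carbon bound to an aromatic nitrogen, and it also carries the fluorine that compound 2 lacks. For the measured compounds named here, no step between measured compounds covers this exchange. The closest guide is compound 2, which carries a branched alkyl at the same position and gives 158000 nM. A step toward a higher number is therefore expected from compound 1 to compound 4, estimated at a 2.5-fold higher number from compound 1 to compound 4 (0.40 log units; beyond the scatter) in this assay. Compound 4 is expected to give about 40000 nM in this assay, with a range from 10000 nM to 160000 nM.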

Compound 4, half-maximal inhibitory concentration: 43700 nM
Beside the measured number, compound 4's estimate is 1.1-fold (0.04 log units) below it; the range from low to high includes it.
By their numbers in this assay, from the lowest: compounds 1, 3 and 4 (each within the scatter of the next, the first and the last beyond it); then compound 2.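

In this assay, for the compounds shown here, this gives the first readable step at this position, a 2.8-fold higher number from compound 1 to compound 4 (0.44 log units; beyond the scatter), with sec-butyl in place of isopropoxymethyl on a saturated chain carbon bound to an aromatic nitrogen. The exchange removes the oxygen and its hydrogen-bond acceptor from the chain, leaves it with one heavy atom fewer and adds a defined stereocentre, and the number moves modestly but beyond the scatter. Nothing measured on these compounds accounts for the step.

The compounds shown leave open whether the step follows the loss of the chain oxygen, the shape of the branching or the defined stereocentre, and how the mirror-image sec-butyl group would compare. They also leave open how a 2-hydroxyethyl chain, a 2-aminoethyl chain or a longer straight alkyl chain would read at this place.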